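This account rests on a few compounds, and the source may have more. Where it says the series, first, only, none or still open, it means among the compounds named here.

Measured so far:
compound 1 `COc1ccc(CN(C)CCCOc2ccc(S(=O)(=O)c3c(C(C)C)cn4ccccc34)cc2)cc1OC` gives 3.18 nM
compound 2 `COc1ccc(CNCCCOc2ccc(S(=O)(=O)c3c(C(C)C)cn4ccccc34)cc2)cc1OC` gives 13 nM
compound 3 `CC(C)(C)NCCCOc1ccc(S(=O)(=O)c2c(C(C)(C)C)cn3ccccc23)cc1` gives 443 nM

In a functional assay (aorta) with Rattus norvegicus as the target (on this read-out lower numbers stand for stronger inhibition and higher numbers for weaker inhibition), compound 2 at 13 nM holds the middle place of the three numbers, with compound 1 lower and compound 3 higher. The next compound to be read is compound 4 `CCCCN(CCCC)CCCOc1ccc(S(=O)(=O)c2c(C(C)C)cn3ccccc23)cc1`, and the change is dibutylamino in place of (3,4-dimethoxybenzyl)amino on a saturated chain carbon, three bonds along the chain from an oxygen on an aromatic ring. In words, dibutylamino replaces (3,4-dimethoxybenzyl)amino on a saturated chain carbon, three bonds along the chain from an oxygen on an aromatic ring.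

Among the measured compounds shown here, only one measured step touches this amine nitrogen: a 4.1-fold higher number from compound 1 to compound 2 (0.61 log units; beyond the scatter), a modest change that swaps methyl for hydrogen. For the measured compounds named here, no measured step removes the benzyl group alone. Compound 3 at 443 nM lacks that group, but its core also differs from that of compound 2, so it gives only a weak hint of a higher number. A small upward move is therefore expected, possibly not beyond the scatter, and the estimated change is a 1.5-fold higher number from compound 2 to compound 4 (0.19 log units; within the scatter). For compound 4 the expected value is 20 nM, with an estimated range from 4 nM to 100 nM.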

Compound 4, half-maximal inhibitory concentration: 21.6 nM
The estimate for compound 4 lay 1.1-fold (0.03 log units) below the measured number, within the range that was stated.
By their numbers in this assay, from the lowest: compound 1; then compounds 2 and 4 (each within the scatter of the next); then compound 3.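

In this assay, dibutylamino in place of (3,4-dimethoxybenzyl)amino gives a 1.7-fold higher number from compound 2 to compound 4 (0.22 log units; within the scatter), so at this position the number stays within the scatter despite a large exchange of groups. The entering group has no ring and no hydrogen-bond donor, which shows that neither the aromatic ring of the benzyl group nor its methoxy oxygens are needed to keep the number in this range, at least with two butyl chains on the nitrogen. No measured property of either group bears on this result.

On these data alone, whether much shorter groups such as dimethylamino, or a ring such as piperidine, would hold the number in the same range stays open. Also open, as far as these compounds go, is how dibutylamino would read on the core of compound 3.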